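The source may hold more compounds than are shown below. What is called first, only, known or untested is meant among the compounds shown, and "the series" means these compounds.

Measured compounds:
compound 1 `O=C(Nc1cccc(/C=C/C(=O)c2nc3ccccc3[nH]2)c1)c1ccccc1` with 2440 nM
compound 2 `Cc1ccccc1S(=O)(=O)Nc1cccc(/C=C/C(=O)c2nc3ccccc3[nH]2)c1` with 955 nM

For the measured compounds named here, in a functional assay on HCT-116 cells (Homo sapiens) for antiproliferative activity, read by MTT assay, with a stated time of 48 h (on this read-out higher numbers stand for weaker inhibition and lower numbers for stronger inhibition), compound 2 holds the lower of the two numbers, since the only measured step, a 2.6-fold lower number from compound 1 to compound 2 (0.41 log units; beyond the scatter), lowered the value by exchanging the whole group on the nitrogen. Compound 3 `Cc1cccc(S(=O)(=O)Nc2cccc(/C=C/C(=O)c3nc4ccccc4[nH]3)c2)c1` differs from compound 2 by 3-methylphenyl in place of 2-methylphenyl on a sulfonyl sulfur. Going by the values given here, no measured step moves a methyl group from one place on that ring to another, so nothing measured so far bears directly on this change, and no shift beyond the scatter is expected. Compound 3 is therefore estimated at 1000 nM with a range of 400 nM to 2500 nM. The expected step is a 1.0-fold higher number from compound 2 to compound 3 (0.02 log units; within the scatter).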

Compound 3, half-maximal inhibitory concentration: 597 nM
For compound 3 the middle estimate is 1.7-fold (0.22 log units) above the measured one; the range from low to high includes it.
By their numbers in this assay, from the lowest: compounds 3 and 2 (each within the scatter of the next); then compound 1.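

Moving the methyl group, with 3-methylphenyl in place of 2-methylphenyl on the sulfonyl sulfur, gives a 1.6-fold lower number from compound 2 to compound 3 (0.20 log units; within the scatter) in this assay, so the two placements cannot be told apart here. The step from the benzoyl group to (3-methylphenyl)sulfonyl on the nitrogen, a 4.1-fold lower number from compound 1 to compound 3 (0.61 log units; beyond the scatter), shows that the earlier gain from a sulfonyl group also appears with this second methyl placement. Nothing available explains these numbers. Open, going by these compounds, is how a plain phenyl ring would read on the sulfonyl sulfur, and whether a methoxy group or a chlorine atom in place of the methyl would shift the number.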